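The source may hold more compounds than are shown below. What is called first, only, known or untested is meant among the compounds shown, and "the series" means these compounds.

Measured compounds in a functional assay on MIA PaCa-2 cells (Homo sapiens) for antiproliferative activity, read by WST assay, with a stated time of 72 h; a higher number here means a weaker inhibitor, a lower number a stronger inhibitor:

- Compound 1 `Cc1noc(-c2cc3ccccc3[nH]2)n1` gives 30500 nM in this assay.
- Compound 2 `COc1ccc2[nH]c(-c3nc(C)no3)cc2c1` reaches only the limit > 50000 nM in this assay.
- Compound 3 `Cc1noc(-c2cc3cc(Cl)ccc3[nH]2)n1` likewise reaches only the limit > 50000 nM in this assay.

For the measured compounds named here, compound 1 is the one member of this set with a number of its own in this assay; the other two sit at the limit of > 50000 nM in this assay, at which 2 of the 3 values shown sit.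

Compound 4 `Clc1ccc(-c2noc(-c3cc4ccccc4[nH]3)n2)cc1` differs from compound 1 in a single place: 4-chlorophenyl in place of methyl on an aromatic carbon. The change sits on the five-membered ring with two nitrogen and one oxygen, whereas both measured steps act on the fused bicyclic part of the shared core. There, the step of an at least 1.6-fold higher number from compound 1 to compound 2 (0.21 log units; that floor lies within the scatter) and the step of an at least 1.6-fold higher number from compound 1 to compound 3 (0.21 log units; that floor lies within the scatter) each move the number up at least to the limit, though the floor of each lies within the scatter. Going by the values given here, neither step touches the place changed in compound 4, so no measured step reads across to it directly; the measured steps only show that the series as a whole sits near or at the limit.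

Among the compounds with values here, with no step to lean on, compound 4 is expected to stay close to compound 1 in this assay, and the step of a 1.3-fold higher number from compound 1 to compound 4 (0.12 log units; within the scatter) is estimated to lie within the scatter. Compound 4 is therefore estimated at 40000 nM in this assay, with a range from 10000 nM to 150000 nM.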

Compound 4, half-maximal inhibitory concentration: 19200 nM
Beside the measured number, compound 4's estimate is 2.1-fold (0.32 log units) above it; low and high end bracket the measured number.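

The change from methyl to 4-chlorophenyl, on an aromatic carbon between two ring nitrogen atoms, gives a 1.6-fold lower number from compound 1 to compound 4 (0.20 log units; within the scatter) in this assay. This is the first change shown at this place on the five-membered ring, and it shows that a group with a six-membered aromatic ring of its own can stand there in place of a single carbon with no step beyond the scatter. Unlike the two changes on the other part of the shared core, which end at a limit of the assay and so give no number, this one leaves a readable value, and the limit stays confined to those two compounds: the limit of > 50000 nM in this assay, at which 2 of the 4 values shown sit.

The compounds shown leave open whether the chlorine or the phenyl ring matters at this place, since plain phenyl, an amine, a carboxylic acid or a longer chain there would each separate what two groups alone cannot. They also leave open whether 4-chlorophenyl at this place would give a readable number when joined with the methoxy or chloro changes on the core.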